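Trifluoromethyl extension of a methoxymethyl side chain

A few compounds are considered here, and "the series" means these few. Any claim that something is new, unique, unknown or untested is made for them only; others in the source may bear on it.

Compound 1, `CCc1cccc2c(OC)c(-c3occ(C)c3C(=S)OC)ccc12`, gives 4.3 ug/mL in a functional assay on KB cells (Homo sapiens) for cytotoxicity, read by MTT assay, with a stated time of 72 h; on this read-out higher numbers stand for an effect only at larger amounts of compound and lower numbers for an effect already at smaller amounts.
Compound 2, `CCc1cccc2c(OC)c(-c3occ(C)c3COC)ccc12`, reaches only a limit of this assay, > 10 ug/mL.

Within the data shown here, the single measured step, an at least 2.3-fold higher number from compound 1 to compound 2 (0.36 log units; beyond the scatter), runs from compound 1 to compound 2. Compound 2 therefore stands at the less potent end of the two values shown, and its value is a limit rather than a number, as the limit of > 10 ug/mL in this assay, at which 1 of the 2 values shown sits, shows.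

Compound 3, `CCc1cccc2c(OC)c(-c3occ(C)c3COCC(F)(F)F)ccc12`, differs from compound 2 by trifluoromethyl in place of hydrogen on a saturated chain carbon bound to an oxygen on a saturated carbon, that is, methoxymethyl becomes (2,2,2-trifluoroethoxy)methyl. Among the measured compounds shown here, no measured step touches this part of the molecule; the only step known concerns a different group on the same aromatic carbon, so nothing measured shows how large an effect this change should have or in which direction.

Starting from a limit, the estimate for compound 3 is 12 ug/mL, with a range from 4 ug/mL to 40 ug/mL, which means a step that the limit leaves unreadable from compound 2 to compound 3 that is expected to stay close to where compound 2 sits, quite possibly again only as a limit.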

Compound 3, concentration for half-maximal effect: 6.6 ug/mL
For compound 3 the middle estimate is 1.8-fold (0.26 log units) above the measured one; measured number inside the range.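

Extending methoxymethyl to (2,2,2-trifluoroethoxy)methyl brings the reading back to a number in this assay: the change gives an at least 1.5-fold lower number from compound 2 to compound 3 (0.18 log units; that floor lies within the scatter), so a side chain of this ether type can give a readable value, although this floor alone does not separate the change from the usual scatter. Only a floor can be given for this step because compound 2 sits at a limit: the limit of > 10 ug/mL in this assay, at which 1 of the 3 values shown sits. The earlier step left unclear whether the group on this aromatic carbon needed sulfur to give a number, and the new comparison, a 1.5-fold higher number from compound 1 to compound 3 (0.19 log units; within the scatter), shows that a group without sulfur can lie within the scatter of the sulfur-bearing one.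

How much of this reading goes with the fluorine atoms and how much with the longer chain stays open: ethoxymethyl, which has hydrogen in place of the fluorine atoms, is not among the compounds shown. Also open, from the compounds shown here alone, is how a hydroxymethyl group or a carboxylic acid on the same aromatic carbon would read in this assay.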